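Working notes: adding a ring methyl to compound 3

This account rests on a few compounds, and the source may have more. Where it says the series, first, only, none or still open, it means among the compounds named here.

Three compounds have numbers in a functional assay on A-375 cells (Homo sapiens) for cytotoxicity, read by MTT assay, with a stated time of 72 h, tested at 1 uM; a lower number here means less inhibition of growth, a higher number more inhibition of growth at the concentration tested. Compound 1 `Cc1ccnc(/C(N)=N/NC(=S)N2CCOCC2)c1` gives 43.2%. Compound 2 `N/C(=N\NC(=S)N1CCCCC1)c1ccccn1` gives 72.5%, and compound 3 `N/C(=N\NC(=S)N1CCCC1)c1ccccn1` gives 65.7%. Going by the values given here, the only single-point step measured so far is a number 6.8 percentage points lower from compound 2 to compound 3 (within the scatter). On these numbers compound 3 stands second of three; its nearest neighbour is compound 2, within the scatter, and its furthest is compound 1, beyond the scatter and lower. Compound 1, however, differs from compound 3 in two places, at the ring and at the group on the thiocarbonyl carbon, so its lower number cannot be assigned to either change alone.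

Compound 4 `Cc1ccnc(/C(N)=N/NC(=S)N2CCCC2)c1` is compound 3 with methyl in place of hydrogen on an aromatic carbon. Among the compounds with values here, no measured step changes only this feature, so none bears on it directly. The pair of compound 1 and compound 2 carries the methyl together with a second change and shows a lower number; on its own that pair suggests only that the methyl is unlikely to raise the number. The step is therefore expected to be modest and downward, a number 10.7 percentage points lower from compound 3 to compound 4 (beyond the scatter), with wide uncertainty. Compound 4 is expected at 55%, between 35% and 72%.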

Compound 4, percent growth inhibition at one concentration: 69%
Estimate against measurement, compound 4: 14 percentage points below, within the range that was stated.
By their numbers in this assay, from the lowest: compound 1; then compounds 3, 4 and 2 (each within the scatter of the next).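

Notes on the ring methyl: in this assay, the first direct reading of this change gives a number 3.3 percentage points higher from compound 3 to compound 4 (within the scatter), so with pyrrolidin-1-yl on the thiocarbonyl carbon, methyl in place of hydrogen on the aromatic carbon opposite the ring nitrogen produces no difference that can be told from the scatter. With the methyl held constant, the series shows a number 25.8 percentage points higher from compound 1 to compound 4 (beyond the scatter), which places a difference beyond the scatter on the exchange of morpholin-4-yl for pyrrolidin-1-yl and means that the low number of compound 1 now goes with the morpholin-4-yl group, not with the methyl. No measurement in hand explains either step.

The compounds shown leave open whether this carbon accepts groups other than methyl, such as methoxy, an amine or a carboxylic acid, without a shift beyond the scatter. They also leave open whether the methyl step would read the same with piperidin-1-yl or morpholin-4-yl on the thiocarbonyl carbon, since it has been read only with pyrrolidin-1-yl.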